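Nitro in place of hydroxy: compound 3 to compound 4

This account rests on a few compounds, and the source may have more. Where it says the series, first, only, none or still open, it means among the compounds named here.

Three compounds of the series have numbers in a functional assay on COLO 320 cells (Homo sapiens) for antiproliferative activity, read by WST assay, with a stated time of 72 h; a lower number here means a stronger inhibitor, a higher number a weaker inhibitor. Compound 1 `Cc1noc(-c2cc3cc(Cl)ccc3[nH]2)n1` gives 19500 nM, compound 2 `c1ccc(-c2noc(-c3cc4ccccc4[nH]3)n2)cc1` gives 12000 nM, and compound 3 `Oc1ccc2[nH]c(-c3nc(-c4ccccc4)no3)cc2c1` gives 15700 nM. All three sit within the scatter of one another, so no order can be read among them. Compound 3 holds the second highest of the three numbers, with compound 1 nearest and compound 2 furthest, both gaps within the scatter.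

Compound 4 `O=[N+]([O-])c1ccc2[nH]c(-c3nc(-c4ccccc4)no3)cc2c1` differs from compound 3 in one place: nitro in place of hydroxy on an aromatic carbon. Going by the values given here, the only measured step at this position is a 1.3-fold higher number from compound 2 to compound 3 (0.12 log units; within the scatter), which lies within the scatter. Among the compounds with values here, no measured step involves a nitro group, so the size of its effect cannot be drawn from the data; the one change seen at this position left the number where it was. The expectation for this assay is therefore a step of a 1.0-fold lower number from compound 3 to compound 4 (0.02 log units; within the scatter), which is to say nothing beyond the scatter. Compound 4 is expected to give about 15000 nM in this assay. For compound 4 the expected range runs from 6000 nM to 40000 nM, reflecting the absence of any nitro-bearing comparison in the set.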

Compound 4, half-maximal inhibitory concentration: 12500 nM
The estimate for compound 4 lay 1.2-fold (0.08 log units) above the measured number; low and high end bracket the measured number.
By their numbers in this assay, from the lowest: compounds 2, 4, 3 and 1 (each within the scatter of the next).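

In this assay this aromatic carbon has now carried hydrogen, hydroxy and nitro: nitro in place of hydroxy gives a 1.3-fold lower number from compound 3 to compound 4 (0.10 log units; within the scatter), and nitro in place of hydrogen gives a 1.0-fold higher number from compound 2 to compound 4 (0.02 log units; within the scatter). Going by these compounds alone, the earlier step at this carbon showed only that hydroxy leaves the number within the scatter of hydrogen; the new steps extend this to a group with 3 heavy atoms and 0 hydrogen-bond donors, replacing one with 1 heavy atom and 1 hydrogen-bond donor, and the result again stays within the scatter, so none of the three groups can be ranked over another at this carbon. Nothing measured here speaks to why the number stays put across these changes.

As far as these compounds go, whether an amine, a carboxylic acid or a longer chain on this carbon would move the number beyond the scatter remains open, as does whether any other carbon of this ring would respond differently. Compound 1 differs from the other compounds in more than one place, so the separate contributions of its chloro and methyl groups also remain unresolved.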